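This account rests on a few compounds, and the source may have more. Where it says the series, first, only, none or still open, it means among the compounds named here.

In a functional assay on B16-F10 cells (Mus musculus) for inhibition, read by MTT assay, with a stated time of 72 h (a lower number here means a stronger inhibitor, a higher number a weaker inhibitor), compound 2 `COc1ccc(Nc2nc(SCc3cn(CC(=O)NC(=O)Nc4ccccn4)nn3)nc(-c3ccc(C(C)C)cc3)c2C#N)cc1` gives 360 nM, the lowest of the three numbers shown. Compound 1 `CC(C)c1ccc(-c2nc(SCc3cn(CC(=O)NC(=O)Nc4ccccn4)nn3)nc(Nc3cccc(C(F)(F)F)c3)c2C#N)cc1` gives 1700 nM and compound 3 `Cc1cccc(Nc2nc(SCc3cn(CC(=O)NC(=O)Nc4ccccn4)nn3)nc(-c3ccc(C(C)C)cc3)c2C#N)c1` gives 1650 nM. The step from compound 1 to compound 2 is a 4.7-fold lower number from compound 1 to compound 2 (0.67 log units; beyond the scatter), that from compound 2 to compound 3 is a 4.6-fold higher number from compound 2 to compound 3 (0.66 log units; beyond the scatter), and that from compound 1 to compound 3 is a 1.0-fold lower number from compound 1 to compound 3 (0.01 log units; within the scatter); all three steps change the group on the ring nitrogen, not the ring studied here.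

Compound 4 `COc1ccc(Nc2nc(SCc3cn(CC(=O)NC(=O)Nc4ccccn4)nn3)nc(-c3ccc(C)cc3)c2C#N)cc1` differs from compound 2 by methyl in place of isopropyl on an aromatic carbon. Among the measured compounds shown here, no measured step touches this position, so the three steps bear on it only indirectly: they show that changes elsewhere in the shared core move this assay by modest amounts. With nothing pointing in either direction, compound 4 is expected to lie near compound 2, with a step of a 1.5-fold higher number from compound 2 to compound 4 (0.18 log units; within the scatter) or none beyond the scatter. The estimate for compound 4 in this assay is 550 nM, within a range from 200 nM to 1500 nM.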

Compound 4, half-maximal inhibitory concentration: 8750 nM
For compound 4 the middle estimate is 16-fold (1.20 log units) below the measured one, outside the stated range (above it).
By their numbers in this assay, from the lowest: compound 2; then compounds 3 and 1 (each within the scatter of the next); then compound 4.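

In this assay, the group on the aromatic carbon para to a large group proves to be a strong determinant of the number: methyl in place of isopropyl gives a 24-fold higher number from compound 2 to compound 4 (1.39 log units; beyond the scatter), a large step from one small change in a carbon-only substituent. The earlier compounds shown here showed only modest steps or none, all from changes to the group on the nitrogen, such as a 4.7-fold lower number from compound 1 to compound 2 (0.67 log units; beyond the scatter), so this position moves the number further than any change seen there, although it rests on this single pair. No measurement shown here accounts for the size of this step.

On these data alone, it remains open whether ethyl, tert-butyl or a longer chain at this place would lie nearer compound 2 or compound 4. As far as these compounds go, it is also open whether a step of this size would recur with 3-methylphenyl or 3-(trifluoromethyl)phenyl on the nitrogen.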